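Carboxy in Place of Methyl: Estimating Compound 4

This account rests on a few compounds, and the source may have more. Where it says the series, first, only, none or still open, it means among the compounds named here.

Three compounds share one core and differ only in the aromatic group attached to it. Compound 1 `COc1cccnc1-c1cc(Cl)ccc1NS(=O)(=O)c1ccc(C(C)(C)C)cc1` gives 958 nM in a functional assay on isolated protein for antagonist activity at C-C chemokine receptor type 9 (Homo sapiens), read by calcium flux, with a stated time of 10 min; a higher number here means a weaker inhibitor, a lower number a stronger inhibitor. Compound 2 `CC(C)(C)c1ccc(S(=O)(=O)Nc2ccc(Cl)cc2-c2ncccc2CO)cc1` gives 89 nM in this assay, and compound 3 `CCNc1nccnc1-c1cc(Cl)ccc1NS(=O)(=O)c1ccc(C(C)(C)C)cc1` gives 421 nM in this assay. Compound 3 therefore stands second highest of the three numbers: the step of a 2.3-fold lower number from compound 1 to compound 3 (0.36 log units; beyond the scatter) places it below compound 1, while the step of a 4.7-fold higher number from compound 2 to compound 3 (0.67 log units; beyond the scatter) places it above compound 2.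

Compound 4 `CC(C)(C)c1ccc(S(=O)(=O)Nc2ccc(Cl)cc2-c2nccnc2NCC(=O)O)cc1` is compound 3 with a single change: carboxy in place of methyl on a saturated chain carbon bound to a nitrogen on an aromatic ring. Within the data shown here, none of the measured steps exchanges a methyl for a carboxy, so the closest guide is an 11-fold lower number from compound 1 to compound 2 (1.03 log units; beyond the scatter), in which a hydroxymethyl replaced a methoxy on the aromatic ring and the number fell markedly. The present change is made on a side chain rather than on the ring itself, and the guide is a single step, so the expectation carries real uncertainty. A modest lowering of the number is nevertheless expected, a 1.9-fold lower number from compound 3 to compound 4 (0.28 log units; within the scatter). Compound 4 is estimated at 220 nM, with a likely range from 60 nM to 800 nM.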

Compound 4, half-maximal inhibitory concentration: 812 nM
Compound 4: middle estimate off by 3.7-fold (0.57 log units), on the low side; the measured number lies above the stated range.
By their numbers in this assay, from the lowest: compound 2; then compounds 3, 4 and 1 (each within the scatter of the next, the first and the last beyond it).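

Exchanging the methyl of the ethylamino group for carboxy gives a 1.9-fold higher number from compound 3 to compound 4 (0.29 log units; within the scatter), so in this assay compound 3 and compound 4 cannot be told apart. Among these compounds, the earlier steps all replaced the whole aromatic group or a substituent on it, and each lay beyond the scatter; this one is the first made on the side chain alone, and it shows that ethylamino can become (carboxymethyl)amino without a measurable shift in the number. The change is not a small one in atom count, since a single carbon leaves and a carboxy of three heavy atoms enters, bringing a hydrogen-bond donor and acceptor that the methyl lacked, yet the read-out stays within the usual spread of repeated measurements.

The compounds shown leave open whether the chain end responds differently to other groups, such as a primary amine, a hydroxyl, a methyl ester or primary amide of the acid, or a longer chain that holds the carboxylic acid further out, and whether any of these would approach compound 2 at 89 nM. Nothing measured here offers a reason for this outcome.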